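The compounds below may be only part of what the source reports. "The series", "measured", "known", "first", "only" and "open" are said of these compounds alone.

Measured in a functional assay on U-251 cells (Homo sapiens) for antiproliferative activity, read by MTT assay, with a stated time of 48 h; a lower number here means a stronger inhibitor, a higher number a weaker inhibitor:
- compound 1 `COc1cc(-c2cccc3nc(-c4ccccc4)oc23)cc(OC)c1OC`: 3500 nM
- compound 2 `COc1ccc(-c2nc3cccc(-c4cc(OC)c(OC)c(OC)c4)c3o2)cc1OC`: 1300 nM
- compound 3 `COc1cc(-c2cccc3nc(-c4ccc(C)cc4)oc23)cc(OC)c1OC`: 3200 nM

Compound 3 sits level with compound 1, since the step of a 1.1-fold lower number from compound 1 to compound 3 (0.04 log units; within the scatter) stays within the scatter. Only compound 2 stands apart, and the step of a 2.5-fold higher number from compound 2 to compound 3 (0.39 log units; beyond the scatter) is modest.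

Compound 4 `COc1cc(-c2cccc3nc(-c4ccco4)oc23)cc(OC)c1OC` carries furan-2-yl in place of the 4-methylphenyl of compound 3, on an aromatic carbon (furan-2-yl in place of 4-methylphenyl on an aromatic carbon). All three measured steps fall at this same place. Methyl in place of hydrogen on the phenyl gave a 1.1-fold lower number from compound 1 to compound 3 (0.04 log units; within the scatter), and 3,4-dimethoxyphenyl in place of phenyl gave a 2.7-fold lower number from compound 1 to compound 2 (0.43 log units; beyond the scatter). The changes seen here are therefore small to modest. Among the compounds with values here, no measured compound has a five-membered ring at this place, so the data give no direction for this swap, and the range must stay wide.

The expected change is a 1.1-fold higher number from compound 3 to compound 4 (0.04 log units; within the scatter), and nothing beyond the scatter is expected in this assay. For compound 4 the estimated value is 3500 nM, with an expected range of 1400 nM to 9000 nM.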

Compound 4, half-maximal inhibitory concentration: 10600 nM
Compound 4: the middle estimate sits 3.0-fold (0.48 log units) below what was measured; measured number outside the range, above it.
By their numbers in this assay, from the lowest: compound 2; then compounds 3 and 1 (each within the scatter of the next); then compound 4.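

In this assay this position, on the aromatic carbon of the five-membered ring with one nitrogen and one oxygen, proves sensitive to the kind of ring attached, and not only to what the phenyl carries: furan-2-yl, the only five-membered ring shown here, weakens the compound against 4-methylphenyl (a 3.3-fold higher number from compound 3 to compound 4 (0.52 log units; beyond the scatter)) and against plain phenyl (a 3.0-fold higher number from compound 1 to compound 4 (0.48 log units; beyond the scatter)). The largest gap is to 3,4-dimethoxyphenyl (an 8.2-fold higher number from compound 2 to compound 4 (0.91 log units; beyond the scatter)), so all three six-membered aromatic rings shown do better than furan-2-yl at this place. Nothing measured here gives a reason for this loss of activity.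

From the compounds shown here alone, whether the loss belongs to five-membered aromatic rings in general or to furan-2-yl alone stays open, and a thiophene at this place would help to separate the two. Going by these compounds, what an amine or a carboxylic acid on the phenyl would do also remains unknown.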